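The compounds below may be only part of what the source reports. "The series", "measured", "known", "first", "only" and "open" are said of these compounds alone.

Measured compounds:
compound 1 `C[C@@H]1CN(c2cccc3c2C[C@H](CN(C)[C@H]2CCCc4cccnc42)NC3)C[C@H](C)N1`: 39 nm/s
compound 2 `CN(C[C@H]1Cc2c(cccc2N2CCN(C3COC3)CC2)CN1)[C@H]1CCCc2cccnc21`: 725 nm/s
compound 3 `c1cnc2c(c1)CCC[C@@H]2N(CC1CCCCC1)C[C@H]1Cc2c(cccc2N2CCNCC2)CN1`: 9 nm/s

In an ADME assay for permeability, using PAMPA, at pH 7.4 (on this read-out higher numbers stand for higher permeability and lower numbers for lower permeability), compound 2 stands highest of the three numbers shown. For the measured compounds named here, the one single-point step present is a 19-fold higher number from compound 1 to compound 2 (1.27 log units; beyond the scatter), a large step, showing that the group on the ring nitrogen of compound 2 moves this read-out strongly. Compound 4 `CN(C[C@H]1Cc2c(cccc2N2CCN(c3cccc(C(F)(F)F)c3)CC2)CN1)[C@H]1CCCc2cccnc21` differs from compound 2 by 3-(trifluoromethyl)phenyl in place of oxetan-3-yl on an amine nitrogen in a ring. Going by the values given here, no measured step exchanges the group on that ring nitrogen in this way, and compound 3 differs from compound 2 in more than one place, so direction is uncertain. The step of a 1.2-fold higher number from compound 2 to compound 4 (0.09 log units; within the scatter) is expected to be small, within the scatter or a little upward. Compound 4 is therefore estimated at 900 nm/s, in the range 300 nm/s to 2700 nm/s.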

Compound 4, apparent permeability: 141 nm/s
Beside the measured number, compound 4's estimate is 6.4-fold (0.81 log units) above it; the measured number lies below the stated range.
By their numbers in this assay, from the lowest: compound 3; then compound 1; then compound 4; then compound 2.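

In this assay, 3-(trifluoromethyl)phenyl in place of oxetan-3-yl on this amine nitrogen gives a 5.1-fold lower number from compound 2 to compound 4 (0.71 log units; beyond the scatter), so the read-out separates two groups at this position that both carry 0 hydrogen-bond donors and no net charge. Oxetan-3-yl thus stands above an aromatic group here, not only above the 3,5-dimethylpiperazin-1-yl comparison. Nothing at hand gives a reason for this step. Open, on these data alone, is how a plain phenyl or a methyl group on that nitrogen would read, and so whether the trifluoromethyl or the aromatic ring accounts for the step.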